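The source may report more compounds than this note shows. Statements on the series, on what has been measured and on what is new or still open speak of the compounds shown alone.

Working notes on the series in a functional assay on MGC-803 cells (Homo sapiens) for inhibition, read by MTT assay, with a stated time of 48 h (on this read-out higher numbers stand for weaker inhibition and lower numbers for stronger inhibition), follow. Compound 1 `C/C=C/C(=O)N(Cc1ccc(OC)c([N+](=O)[O-])c1)c1cc(OC)c(OC)c(OC)c1` gives 590 nM and compound 3 `COc1ccc(CN(C(=O)C(C)Br)c2cc(OC)c(OC)c(OC)c2)cc1O` gives 120 nM in this read-out. Compound 2 `COc1ccc(CNc2cc(OC)c(OC)c(OC)c2)cc1[N+](=O)[O-]` gives 19400 nM and holds the highest number of the three, beyond the scatter from both others.

Compound 4 `COc1ccc(CNc2cc(OC)c(OC)c(OC)c2)cc1Cl` is still unmeasured. It carries chloro in place of nitro on an aromatic carbon, ortho to a methoxy group, and the count of that difference is chloro in place of nitro on an aromatic carbon in full.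

For the measured compounds named here, the one measured step is a 33-fold higher number from compound 1 to compound 2 (1.52 log units; beyond the scatter) and it is large, but it concerns the (prop-1-en-1-yl)carbonyl on a nitrogen, not this place. Compound 4 keeps the hydrogen on that nitrogen, as does compound 2 at 19400 nM in the same read-out. Going by the values given here, no measured pair isolates the nitro to chloro change, and compound 3 differs in more than one place, so the expectation is weakly grounded. The estimated step is a 1.2-fold lower number from compound 2 to compound 4 (0.08 log units; within the scatter) and none beyond the scatter is expected. For compound 4 the expected value is 16000 nM with an estimated range from 6000 nM to 45000 nM.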

Compound 4, half-maximal inhibitory concentration: 46200 nM
For compound 4 the middle estimate is 2.9-fold (0.46 log units) below the measured one; measured number outside the range, above it.
By their numbers in this assay, from the lowest: compound 3; then compound 1; then compound 2; then compound 4.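

At the aromatic carbon ortho to a methoxy group, chloro in place of nitro gives a 2.4-fold higher number from compound 2 to compound 4 (0.38 log units; beyond the scatter) in this assay, so this position responds to a change of group while the hydrogen on the nitrogen stays. For the compounds shown here, until now the only one-place step was the large one at the nitrogen, a 33-fold higher number from compound 1 to compound 2 (1.52 log units; beyond the scatter); this modest step is the first reading for a change on the aromatic ring itself. No measurement shown here bears on why nitro and chloro differ at this position.

The compounds shown leave open whether chloro in place of nitro moves the number the same way when the nitrogen carries (prop-1-en-1-yl)carbonyl, as in compound 1. They also leave open how an amine or a carboxylic acid on this aromatic carbon would compare with nitro and chloro.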